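The source may report more compounds than this note shows. Statements on the series, on what has been measured and on what is new or still open speak of the compounds shown alone.

In an ADME assay on Vero cells (Chlorocebus sabaeus) for cytotoxicity, read by MTT assay, with a stated time of 72 h (a lower number here means a stronger inhibitor, a higher number a weaker inhibitor), compound 1 `CCCC[S+]([O-])CCCCN=C=S` gives 5150 nM and compound 2 `CC(C)[S+]([O-])CCCCN=C=S` gives 10400 nM, so compound 2 holds the higher of the two numbers and is the weaker inhibitor of this pair. Within the data shown here, the only measured step is a 2.0-fold higher number from compound 1 to compound 2 (0.31 log units; beyond the scatter), and it comes from isopropyl taking the place of butyl on a sulfur. Compound 3 `CC(C)[S+]([O-])CCCN=C=S` keeps that isopropyl but differs from compound 2 elsewhere: a group of 3 heavy atoms (1 carbon, 1 nitrogen, 1 sulfur; no ring) in place of a group of 4 heavy atoms (2 carbon, 1 nitrogen, 1 sulfur; no ring), on a saturated chain carbon, three bonds along the chain from a sulfur. Among the measured compounds shown here, this change lies on a saturated chain carbon, three bonds along the chain from a sulfur, a place that no measured step has tested. For the measured compounds named here, the one modest step is therefore only a loose guide. No change beyond the scatter is expected, with an estimated 1.2-fold higher number from compound 2 to compound 3 (0.06 log units; within the scatter). For compound 3, the estimated value is 12000 nM, with an expected range from 5500 nM to 26000 nM.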

Compound 3, half-maximal inhibitory concentration: 8250 nM
Beside the measured number, compound 3's estimate is 1.5-fold (0.16 log units) above it, and the stated range covers the measured number.
By their numbers in this assay, from the lowest: compounds 1, 3 and 2 (each within the scatter of the next, the first and the last beyond it).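

Read in this assay, a 1.3-fold lower number from compound 2 to compound 3 (0.10 log units; within the scatter) is the first reading at this place, on a saturated chain carbon, three bonds along the chain from a sulfur. Replacing the group of 4 heavy atoms with the group of 3 heavy atoms therefore leaves no change that can be told from ordinary assay variation, whereas the earlier step tested only the group on the sulfur. Nothing here offers a measured explanation for this result.

One small change cannot show whether this place tolerates larger changes, so a longer chain, or an amine or a carboxylic acid at the same place, could give a different result. On these data alone, it also remains open whether the same change would give a similar result with butyl rather than isopropyl on the sulfur.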